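Trading a ring-bearing group for an open chain

The source may hold more compounds than are shown below. What is called first, only, known or untested is meant among the compounds shown, and "the series" means these compounds.

Measured so far in a physicochemical assay for solubility, read by LC-MS, in phosphate buffer, with a stated time of 24 h, at pH 7.4; on this read-out higher numbers stand for higher solubility and lower numbers for lower solubility
compound 1 `CN(c1ncco1)c1cnc(NCc2c(F)ccc3c2CCO3)n2cnnc12` gives 67000 nM
compound 2 `Cn1nccc1-c1cnc(NCc2c(F)ccc3c2CCO3)c2cn[nH]c(=O)c12` gives 2000 nM

Compound 1 holds the higher of these two numbers, and its gap to compound 2 lies beyond the usual scatter of repeated measurements. The two compounds differ in more than one place, so that gap says little about any single change.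

Compound 3 (`COCCC(=O)Nc1cnc(NCc2c(F)ccc3c2CCO3)n2cnnc12`) keeps the core of compound 1 but carries ((2-methoxyethyl)carbonyl)amino in place of methyl(1,3-oxazol-2-yl)amino on an aromatic carbon. Among the compounds with values here, no measured pair shows this swap alone, so the expectation starts from compound 1 (67000 nM) and stays cautious. In this assay no step beyond the scatter is expected, with a slight lean downward (a 1.5-fold lower number from compound 1 to compound 3 (0.17 log units; within the scatter)). For compound 3 the estimated value is 45000 nM (expected range 12000 nM to 130000 nM).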

Compound 3, solubility: 980000 nM
The estimate for compound 3 lay 22-fold (1.34 log units) below the measured number; measured number above the stated range.
By their numbers in this assay, from the lowest: compound 2; then compound 1; then compound 3.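

In this assay, putting ((2-methoxyethyl)carbonyl)amino in place of methyl(1,3-oxazol-2-yl)amino on this aromatic carbon gives a 15-fold higher number from compound 1 to compound 3 (1.17 log units; beyond the scatter) and is the only single-place comparison shown, so the number clearly depends on what this position carries. The two groups match in heavy-atom count, yet the entering group has no ring and has 1 hydrogen-bond donor where the leaving group has 0. No measurement shown says which of these differences lies behind the change.

From the compounds shown here alone, the swap alters several features at once, so it remains open whether the carbonyl-linked amino unit or the methoxyethyl end matters more; acetylamino, or a chain ending in an amine or a carboxylic acid, would help separate them. Going by these compounds, it also remains open whether the same swap would give a similar step on the core of compound 2.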